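A few compounds are considered here, and "the series" means these few. Any claim that something is new, unique, unknown or untested is made for them only; others in the source may bear on it.

Measured compounds in a functional assay on cells (Cancer cell lines, Homo sapiens) for inhibition; on this read-out lower numbers stand for stronger inhibition of growth and higher numbers for weaker inhibition of growth:

Compound 1, `Cc1cc(-c2nc3sc(C)cn3c2/C=N/NC(=N)N)c(C)s1`, gives 14100 nM.
Compound 2, `Cc1cn2c(/C=N/NC(=N)N)c(-c3cccs3)nc2s1`, gives 4270 nM.
Compound 3, `Cc1cc(-c2nc3n(c2/C=N/NC(=N)N)CCS3)c(C)s1`, gives 17400 nM.

Compound 1 and compound 2 share one core and differ in a single place: thiophen-2-yl in place of 2,5-dimethylthiophen-3-yl on an aromatic carbon. This exchange produced a 3.3-fold lower number from compound 1 to compound 2 (0.52 log units; beyond the scatter), a step that lies beyond the usual scatter of this assay. Compound 3 is built on a different core; how the core of compound 3 differs from the core of compound 1 is not broken down here. Its value in this assay is within the scatter of the value of compound 1, while it lies beyond the scatter from the value of compound 2.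

Compound 4, `N=C(N)N/N=C/c1c(-c2cccs2)nc2n1CCS2`, is not yet measured. It stands to compound 3 as compound 2 stands to compound 1: thiophen-2-yl in place of 2,5-dimethylthiophen-3-yl on an aromatic carbon. The surroundings of the place are not identical, since in compound 3 the carbon carrying the group is also two ring bonds from two ring atoms that each bear a fused ring, so this is the same kind of change rather than the same change. Because the earlier exchange gave a 3.3-fold lower number from compound 1 to compound 2 (0.52 log units; beyond the scatter), a step of similar size, a 3.2-fold lower number from compound 3 to compound 4 (0.50 log units; beyond the scatter), is expected here, with some extra uncertainty from the different core. Compound 4 is therefore estimated at 5500 nM in this assay, expected to fall between 2500 nM and 12000 nM.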

Compound 4, concentration for 50% growth inhibition: 22900 nM
The estimate for compound 4 lay 4.2-fold (0.62 log units) below the measured number, and the stated range ends below it.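

In this assay, putting thiophen-2-yl in place of 2,5-dimethylthiophen-3-yl on the core of compound 3 gives a 1.3-fold higher number from compound 3 to compound 4 (0.12 log units; within the scatter) and so produces no difference that can be told apart from the ordinary variation between repeated measurements. The same exchange on the core of compound 1 did produce a real step, so this change does not carry over with a fixed size from one core to the other in this series: the same change on two cores in this assay, a 3.3-fold lower number (0.52 log units; beyond the scatter) from compound 1 to compound 2 and a 1.3-fold higher number (0.12 log units; within the scatter) from compound 3 to compound 4, 4.3-fold (0.64 log units) apart, beyond the scatter of two such steps. For the compounds shown here, this rests on only two matched pairs, so it shows that the core can matter for this exchange, but it does not show which feature of the core is responsible, nor which of the two results would be more typical on a further core.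

The compounds shown leave open whether the two methyl groups act together or one alone accounts for the step seen on the core of compound 1, which a thiophene carrying a single methyl on each core could help to separate. They also leave open how quite different groups at this aromatic carbon, such as a phenyl ring or an amine, would behave on these two cores.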